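A few compounds are considered here, and "the series" means these few. Any claim that something is new, unique, unknown or untested is made for them only; others in the source may bear on it.

Measured in a functional assay on LM7 cells (Homo sapiens) for antiproliferative activity, read by MTT assay, with a stated time of 72 h; a higher number here means a weaker inhibitor, a lower number a stronger inhibitor:

Compound 1 `COc1ccc2occ(CSC(=S)N(C(C)C)C(C)C)c(=O)c2c1` gives 4700 nM.
Compound 2 `COc1ccc2occ(CSC(=S)N3CCOCC3)c(=O)c2c1` gives > 40000 nM, which is a limit of the assay and not a number.
Compound 3 `COc1ccc2occ(CSC(=S)N3CCCC3)c(=O)c2c1` gives 6000 nM.

Compound 3 holds the highest of the two numbers, with compound 1 nearest; the step of a 1.3-fold higher number from compound 1 to compound 3 (0.11 log units; within the scatter) lies within the scatter, so no order between the two can be read. Compound 4 `COc1ccc2occ(CSC(=S)N3CCCCC3)c(=O)c2c1` differs from compound 3 in one place: piperidin-1-yl in place of pyrrolidin-1-yl on a thiocarbonyl carbon. For the measured compounds named here, no measured step exchanges these two rings directly. The nearest guide is a 1.3-fold higher number from compound 1 to compound 3 (0.11 log units; within the scatter), where one amine replaced another and the number stayed within the scatter, whereas an at least 6.6-fold lower number from compound 2 to compound 3 (0.82 log units; beyond the scatter) shows that a different amine moved the number beyond it. Without a direct precedent, a step within the scatter is expected in this assay. Compound 4 is therefore expected to give 6000 nM, within 2500 nM to 15000 nM. The expected step is no change at the digits printed from compound 3 to compound 4 (within the scatter).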

Compound 4, half-maximal inhibitory concentration: 4700 nM
For compound 4 the middle estimate is 1.3-fold (0.11 log units) above the measured one; measured number inside the range.
By their numbers in this assay, from the lowest: compounds 1, 4 and 3 (each within the scatter of the next). At a limit, above all of these: compound 2.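

Putting piperidin-1-yl in place of pyrrolidin-1-yl on a thiocarbonyl carbon gives a 1.3-fold lower number from compound 3 to compound 4 (0.11 log units; within the scatter), and putting it in place of diisopropylamino gives no change at the digits printed from compound 1 to compound 4 (within the scatter), so in this assay these three amine groups cannot be told apart. Only morpholin-4-yl stands apart, with an at least 8.5-fold lower number from compound 2 to compound 4 (0.92 log units; beyond the scatter). That step starts from a limit of the assay, not a number: the limit of > 40000 nM in this assay, at which 1 of the 4 values shown sits.

From the compounds shown here alone, whether a piperazine ring or a small open-chain amine such as dimethylamino would fall with compound 2 or with the other three stays open.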